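Thioether series on the shared core: compound 4 outlook

The compounds below may be only part of what the source reports. "The series", "measured", "known", "first", "only" and "open" are said of these compounds alone.

Compound 2 `CCCCCCSc1nc2ccccc2n1CC(=O)O` sits second highest of the three numbers in hand: in an assay on HEK293 cells for displacement of a labelled ligand from prostaglandin D2 receptor 2 (Homo sapiens) (a higher number here means a weaker inhibitor, a lower number a stronger inhibitor), compound 2 gives 1360 nM. Compound 1 `O=C(O)Cn1c(SCCCc2ccccc2)nc2ccccc21` gives 475 nM and compound 3 `CCOC(=O)CCCCSc1nc2ccccc2n1CC(=O)O` gives 2360 nM, so compound 2 lies nearer to compound 3 than to compound 1. The measured steps are a 2.9-fold higher number from compound 1 to compound 2 (0.46 log units; beyond the scatter), a 5.0-fold higher number from compound 1 to compound 3 (0.70 log units; beyond the scatter) and a 1.7-fold higher number from compound 2 to compound 3 (0.24 log units; within the scatter).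

Compound 4 `O=C(O)Cn1c(SCc2cccc(Br)c2)nc2ccccc21` differs from compound 2 in one place: 3-bromophenyl in place of pentyl on a saturated chain carbon bound to a sulfur. Within the data shown here, the step that bears on this is the one from compound 1 to compound 2, where a phenyl gave way to propyl and the number rose by a 2.9-fold higher number from compound 1 to compound 2 (0.46 log units; beyond the scatter); compound 4 brings a six-membered aromatic ring of carbon only back onto the thioether chain, though on the carbon bound to the sulfur rather than three bonds along, and with a bromine on it. Among the measured compounds shown here, no measured pair shows the effect of that shorter placement or of the bromine, so the size is uncertain. A gain on compound 2 of roughly the magnitude seen between compound 1 and compound 2 is expected, in the direction of a lower number, as a 3.0-fold lower number from compound 2 to compound 4 (0.48 log units; beyond the scatter). Compound 4 is therefore estimated at 450 nM, with a range from 150 nM to 1300 nM.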

Compound 4, half-maximal inhibitory concentration: 370 nM
Estimate against measurement, compound 4: 1.2-fold (0.09 log units) above, within the range that was stated.
By their numbers in this assay, from the lowest: compounds 4 and 1 (each within the scatter of the next); then compounds 2 and 3 (each within the scatter of the next).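

The ring result extends what compounds 1 and 2 showed: the 3-bromophenyl in place of pentyl, on a saturated chain carbon bound to a sulfur, gives a 3.7-fold lower number from compound 2 to compound 4 (0.57 log units; beyond the scatter). Among these compounds, the earlier gain from an aromatic ring was seen only with the ring three bonds along the chain from the sulfur, so this is the first sign that a ring on the carbon bound to the sulfur also goes with a lower number than a saturated chain, and that the ring can carry a bromine without losing that gain. Compound 1 at 475 nM and compound 4 at 370 nM lie within the scatter of each other, but no measurement in hand accounts for the gain at either ring placement.

Because ring and bromine enter together, the shown compounds do not separate their shares of the step, so a plain phenyl on the same carbon would be the direct test of the bromine. Also open, as far as these compounds go, are a chloro group in place of the bromine, a pyridine ring in place of the benzene ring, and a two-carbon link between the sulfur and the ring.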